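This account rests on a few compounds, and the source may have more. Where it says the series, first, only, none or still open, it means among the compounds named here.

Measured compounds in an assay on isolated protein for inhibition of advanced glycosylation end product-specific receptor (Homo sapiens), read by FRET, with stated times of 30 min and 1 h, tested at 4 uM; a lower number here means less inhibition, a higher number more inhibition at the concentration tested (going by the name of the read-out):
compound 1, `Clc1ccc(Oc2ccc3nc(-c4ccc(OCC5CCNCC5)cc4)oc3c2)cc1` — compound 1 gives "not active" (no number reported)
compound 2, `CN1CCC(Oc2ccc(-c3nc4ccc(Oc5ccc(Cl)cc5)cc4o3)cc2)CC1` — compound 2 gives 19.5%
compound 3, `CC(C)N1CCC(Oc2ccc(-c3nc4ccc(Oc5ccc(Cl)cc5)cc4o3)cc2)CC1` — compound 3 gives 12.7%

Among the measured compounds shown here, compound 3 holds the lower of the two reported numbers in this assay, but the only measured step, a number 6.8 percentage points lower from compound 2 to compound 3 (within the scatter), lies within the scatter, so compounds 2 and 3 are not separated by these data. Compound 1 is reported without a number.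

Compound 4, `Clc1ccc(Oc2ccc3nc(-c4ccc(OCCCN5CCNCC5)cc4)oc3c2)cc1`, differs from compound 3 in one place: 3-(piperazin-1-yl)propyl in place of 1-isopropylpiperidin-4-yl on an oxygen on an aromatic ring. The measured step of a number 6.8 percentage points lower from compound 2 to compound 3 (within the scatter) alters only the group on the ring nitrogen and keeps the rest of the side chain, so it gives no direct guide to exchanging the whole side chain. Compound 1, whose side chain also lacks a substituent on its ring nitrogen, is reported as "not active" (no number reported). Both reported numbers are low and neither measured step nor compound points to stronger inhibition. The step of a number 4.7 percentage points lower from compound 3 to compound 4 (within the scatter) is therefore expected to stay within the scatter or drift toward no reported activity. The estimate for compound 4 in this assay is 8%, with a range of 0% to 20%.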

Compound 4, a percentage reported as inhibition, at one concentration (the size of the read-out at that concentration, not a potency): 42.7%
Compound 4: middle estimate off by 34.7 percentage points, on the low side; measured number outside the range, above it.
By their numbers in this assay, from the lowest: compounds 3 and 2 (each within the scatter of the next); then compound 4.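

In this assay, the group on the oxygen on the aromatic ring is the only place among the compounds shown where a change separates compounds: exchanging a substituted piperidin-4-yl group for 3-(piperazin-1-yl)propyl gives a number 30 percentage points higher from compound 3 to compound 4 (beyond the scatter) and a number 23.2 percentage points higher from compound 2 to compound 4 (beyond the scatter). The position therefore responds to an exchange of the whole side chain, which the swap of methyl for isopropyl on the ring nitrogen could not show, and an unsubstituted ring nitrogen does not by itself settle the outcome: compound 1, which has one, is reported as "not active" (no number reported), while compound 4, which also has one, gives 42.7%. No supporting data are available to account for this difference in the read-out.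

The change alters the ring and its attachment to the oxygen together, so the compounds shown do not tell whether the propyl chain, the second ring nitrogen or their combination carries the step. A 3-(piperidin-1-yl)propyl group would isolate the second ring nitrogen, while a longer chain ending in the same piperazine would test the chain length.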